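A few compounds are considered here, and "the series" means these few. Any claim that something is new, unique, unknown or untested is made for them only; others in the source may bear on it.

Measured so far in a functional assay on NCI-H460 cells (Homo sapiens) for inhibition, read by sulforhodamine B assay, with a stated time of 48 h; a higher number here means a weaker inhibitor of growth, a lower number a stronger inhibitor of growth:
compound 1 `N#CCC1=C(C#N)CC(c2ccc(Br)cc2)=C(CC(=O)c2ccc(Br)cc2)O1` gives 10400 nM
compound 2 `N#CCC1=C(C#N)CC(c2ccc([N+](=O)[O-])cc2)=C(CC(=O)c2ccc([N+](=O)[O-])cc2)O1` gives 80 nM
compound 3 `N#CCC1=C(C#N)CC(c2ccc([N+](=O)[O-])cc2)=C(CC(=O)c2ccc(Br)cc2)O1` gives 3600 nM

Compound 2 holds the lowest number of the three, at 80 nM in this assay. Compound 4 `N#CCC1=C(C#N)CC(c2ccc(Br)cc2)=C(CC(=O)c2ccc([N+](=O)[O-])cc2)O1` is not yet measured. It differs from compound 2 by bromo in place of nitro on an aromatic carbon, 4-nitrophenyl to 4-bromophenyl bromo in place of nitro on an aromatic carbon while the nitro on the other ring stays.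

For the measured compounds named here, two measured steps bear on this. The closer guide is a 2.9-fold lower number from compound 1 to compound 3 (0.46 log units; beyond the scatter) as it exchanges the same two groups on the same ring, though in the reverse sense and with bromo on the other ring. That step is modest. The swap of bromo for nitro on the other ring gives a 45-fold higher number from compound 2 to compound 3 (1.65 log units; beyond the scatter) which is large. On these data alone, the same-ring swap has not been seen with nitro on the other ring, so a larger rise stays open.

A modest rise is therefore expected, with the estimated step being a 3.5-fold higher number from compound 2 to compound 4 (0.54 log units; beyond the scatter) in this assay overall. For compound 4 the estimate is 280 nM with an expected range of 100 nM to 1500 nM in this assay as well.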

Compound 4, concentration for 50% growth inhibition: 10 nM
Compound 4: middle estimate off by 28-fold (1.45 log units), on the high side, outside the stated range (below it).
By their numbers in this assay, from the lowest: compound 4; then compound 2; then compound 3; then compound 1.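

In this assay the step to 4-bromophenyl with nitro kept on the other ring lowers the number (an 8.0-fold lower number from compound 2 to compound 4 (0.90 log units; beyond the scatter)), so the direction of this change at this position depends on what the other ring carries: the same change on two cores in this assay, a 2.9-fold lower number (0.46 log units; beyond the scatter) from compound 1 to compound 3 and an 8.0-fold higher number (0.90 log units; beyond the scatter) from compound 4 to compound 2, 23-fold (1.36 log units) apart, beyond the scatter of two such steps.
The swap on the other ring is also much larger with nitro rather than bromo at this position (a 1000-fold lower number from compound 1 to compound 4 (3.02 log units; beyond the scatter)): the same change on two cores in this assay, a 45-fold higher number (1.65 log units; beyond the scatter) from compound 2 to compound 3 and a 1000-fold higher number (3.02 log units; beyond the scatter) from compound 4 to compound 1, 23-fold (1.36 log units) apart, beyond the scatter of two such steps.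
The two rings therefore do not contribute independently across these four compounds, and a nitro and a bromo in the arrangement of compound 4 outperform two nitro groups in compound 2, whereas the reversed arrangement in compound 3 does not.

On these data alone, what underlies this coupling stays open. Also open, as far as these compounds go, is whether it extends beyond bromo and nitro, for instance to an amine or a methoxy group at this position.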